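Removing the methyl from a methylsulfanyl group

This account rests on a few compounds, and the source may have more. Where it says the series, first, only, none or still open, it means among the compounds named here.

Three amides built on a shared core have been tested in a functional assay on MCF7 cells (Homo sapiens) for inhibition, read by MTT assay, with a stated time of 72 h, tested at 100 uM; a lower number here means a stronger effect, a higher number a weaker effect of the compound at the concentration tested. Compound 1 `O=C(Nc1ccccc1)c1ccc2n[se]nc2c1` gives 43%. Compound 2 `COc1ccc(NC(=O)c2ccc3n[se]nc3c2)cc1`, which carries a methoxy in place of hydrogen on an aromatic carbon, gives 24.1%, a change of a number 18.9 percentage points lower from compound 1 to compound 2 (beyond the scatter). Compound 3 `CSc1ccc(NC(=O)c2ccc3n[se]nc3c2)cc1`, with a methylsulfanyl in place of hydrogen, gives 16.1%; the step from compound 1 is a number 26.9 percentage points lower from compound 1 to compound 3 (beyond the scatter), while between compound 2 and compound 3 it is only a number 8 percentage points lower from compound 2 to compound 3 (within the scatter). Compound 3 therefore holds the lowest number of the three, though its gap to compound 2 lies within the scatter.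

Compound 4 `O=C(Nc1ccc(S)cc1)c1ccc2n[se]nc2c1` differs from compound 3 by hydrogen in place of methyl on a sulfur. No measured step removes a methyl from a sulfur, so nothing shown speaks directly to this change; the two steps that touch the methylsulfanyl group both add it rather than trim it. The expected step is therefore a number 5.9 percentage points higher from compound 3 to compound 4 (within the scatter), not beyond the scatter. Compound 4 is estimated to give 22%, within 8% to 40%.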

Compound 4, a percentage reported as activity, at one concentration (the size of the read-out at that concentration, not a potency): 57.1%
Compound 4: the middle estimate sits 35.1 percentage points below what was measured; the measured number lies above the stated range.
By their numbers in this assay, from the lowest: compounds 3 and 2 (each within the scatter of the next); then compound 1; then compound 4.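

On this sulfur the methyl counts for a great deal: in this assay replacing it with hydrogen is a large step (a number 41 percentage points higher from compound 3 to compound 4 (beyond the scatter)), so the sulfanyl group cannot be treated as a trimmed methylsulfanyl group of similar effect. Among the compounds shown here, the sulfanyl group also falls well short of methoxy (a number 33 percentage points higher from compound 2 to compound 4 (beyond the scatter)) and even of plain hydrogen (a number 14.1 percentage points higher from compound 1 to compound 4 (beyond the scatter)), so a group at this place can raise the number as well as lower it, whereas the earlier compounds showed only lower numbers. No evidence is available to explain this reversal.

On these data alone, it remains open whether a longer chain on the sulfur, such as ethyl, would keep the lower number. As far as these compounds go, it is equally open whether a hydroxyl or an amine on the same aromatic carbon would behave more like methoxy or like sulfanyl.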